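Compound 2 to compound 4 at the assay limit

The source may hold more compounds than are shown below. What is called first, only, known or untested is meant among the compounds shown, and "the series" means these compounds.

Compound 1 (`O=C(NNc1ccc(F)cc1)c1cccc(NS(=O)(=O)c2cnc(O)nc2O)c1`), compound 2 (`Cc1cccc(NNC(=O)c2ccccc2NS(=O)(=O)c2cnc(O)nc2O)c1`) and compound 3 (`Cc1ccccc1C(=O)NNC(=O)c1cccc(NS(=O)(=O)c2cnc(O)nc2O)c1`) have all been read in a functional assay on SGC-7901 cells (Homo sapiens) for antiproliferative activity, read by MTT assay, with a stated time of 24 h (a higher number here means a weaker inhibitor, a lower number a stronger inhibitor), without a number emerging. Compound 2 gives > 20000 nM as a limit and not a number, so it holds no rank in the series. Compound 1 gives > 20000 nM as a limit. Compound 3 gives > 20000 nM as a limit. Compound 4 (`Cc1ccccc1C(=O)NNC(=O)c1ccccc1NS(=O)(=O)c1cnc(O)nc1O`) follows from compound 2 with (2-methylphenyl)carbonyl in place of 3-methylphenyl on an amine nitrogen. Within the data shown here, the one measured step bearing on this is a step that the two limits leave unreadable from compound 1 to compound 3 where the same group enters in place of 4-fluorophenyl. Beyond that stands only the limit of > 20000 nM in this assay, at which 3 of the 3 values shown sit, and no sign of a change. No step beyond the scatter is therefore expected in this assay and no direction can be given. The estimated step is a step that the limit leaves unreadable from compound 2 to compound 4 and it is expected to stay within the scatter. For compound 4 the expected value is 25000 nM with an estimated range of 12000 nM to 60000 nM and another limit is the likeliest report.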

Compound 4, half-maximal inhibitory concentration: 13000 nM
Compound 4: middle estimate off by 1.9-fold (0.28 log units), on the high side; measured number inside the range.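

In this assay, replacing 3-methylphenyl with (2-methylphenyl)carbonyl on the amine nitrogen gives an at least 1.5-fold lower number from compound 2 to compound 4 (0.18 log units; that floor lies within the scatter). Among these compounds, this is the first sign that the position can respond to this change, although the printed floor does not establish a change beyond the scatter, and the step from compound 1 to compound 3 with the same incoming group cannot be read. Compound 4 is the only compound shown with a number rather than a limit, and it stands against this background: the limit of > 20000 nM in this assay, at which 3 of the 4 values shown sit.

From the compounds shown here alone, whether the true step from the limit of compound 2 exceeds the scatter remains open. Also open, going by these compounds, is whether the carbonyl or the 2-methylphenyl ring matters more, which an acetyl or unsubstituted benzoyl group on the same amine nitrogen could separate.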